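Ethoxy extension of the methoxy chain in compound 2

The compounds below may be only part of what the source reports. "The series", "measured", "known", "first", "only" and "open" are said of these compounds alone.

Of the compounds shown here, two have been measured in a physicochemical assay for lipophilicity, measured as octanol-water partition; a higher number here means a more lipophilic compound, a lower number a more polar compound. Compound 1 `CCCCc1c(Cl)cc(N/C=N/OCC)cc1Cl` gives 5.6 in this assay. Compound 2 `C#CCc1c(Cl)cc(N/C=N/OC)cc1Cl` gives 3.3 in this assay, the lower of the two numbers, with compound 1 standing higher by a gap beyond the usual scatter. Compound 3 `C#CCc1c(Cl)cc(N/C=N/OCOCC)cc1Cl` differs from compound 2 by ethoxy in place of hydrogen on a saturated chain carbon bound to an oxygen. Among the measured compounds shown here, no measured pair shows this change in isolation. A rise beyond the scatter is expected, with the step from compound 2 to compound 3 in this assay estimated at a number 0.60 log units higher from compound 2 to compound 3 (beyond the scatter). Compound 3 is expected to give about 3.9 in this assay, within a range from 3.3 to 4.5.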

Compound 3, partition coefficient: 3.5
The estimate for compound 3 lay 0.40 log units above the measured number; low and high end bracket the measured number.
By their numbers in this assay, from the lowest: compounds 2 and 3 (each within the scatter of the next); then compound 1.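

Among the compounds shown here, compound 2 and compound 3 form the first pair that differs in one place, so this change can now be read on its own. In this assay, ethoxy in place of hydrogen on a saturated chain carbon bound to an oxygen gives a number 0.20 log units higher from compound 2 to compound 3 (within the scatter) and so separates the two compounds by no more than repeated measurements would. No measurement at hand accounts for the size of this step.

From the compounds shown here alone, whether a longer chain or an amine on this carbon would give a step beyond the scatter stays open. Going by these compounds, whether ethoxy gives the same step on the core of compound 1 also stays open.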